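The compounds below may be only part of what the source reports. "The series", "measured", "known", "first", "only" and "open" are said of these compounds alone.

Measured in a functional assay on NCI-H1581 cells (Homo sapiens) for antiproliferative activity, read by CCK-8 assay, with a stated time of 72 h; on this read-out lower numbers stand for stronger inhibition and higher numbers for weaker inhibition:
- compound 1 `COc1cc(OC)c(Cl)c(-c2ccc3c(NC(=O)c4ccc(N5CCCN(C)CC5)cc4)n[nH]c3n2)c1Cl` gives 1.3 nM
- compound 2 `CCN1CCN(c2ccc(C(=O)Nc3n[nH]c4nc(-c5c(Cl)c(OC)cc(OC)c5Cl)ccc34)cc2)CC1` gives 0.7 nM
- compound 3 `COc1cc(OC)c(Cl)c(-c2ccc3c(NC(=O)c4ccc(N5CCN(C6CCC6)CC5)cc4)n[nH]c3n2)c1Cl` gives 2.3 nM

Among the compounds with values here, the one step beyond the scatter in this set is a 3.3-fold higher number from compound 2 to compound 3 (0.52 log units; beyond the scatter). The other two, a 1.9-fold lower number from compound 1 to compound 2 (0.27 log units; within the scatter) and a 1.8-fold higher number from compound 1 to compound 3 (0.25 log units; within the scatter), stay within it. Compound 3 therefore holds the highest number of the set, but it is separated only from compound 2.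

Compound 4 `COc1cc(OC)c(Cl)c(-c2ccc3c(NC(=O)c4ccc(N5CCN(S(C)(=O)=O)CC5)cc4)n[nH]c3n2)c1Cl` follows from compound 3 with methylsulfonyl in place of cyclobutyl on an amine nitrogen in a ring. Within the data shown here, the closest precedent is the change at the same nitrogen, a 3.3-fold higher number from compound 2 to compound 3 (0.52 log units; beyond the scatter), which was modest. Among the measured compounds shown here, no measured compound carries a sulfonyl group on this nitrogen, so the data give neither the direction nor the size of this change directly. A modest rise is the working expectation, held loosely, and the expected step is a 2.6-fold higher number from compound 3 to compound 4 (0.42 log units; beyond the scatter).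

Compound 4 is estimated at 6 nM, with an expected range of 1.5 nM to 25 nM.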

Compound 4, half-maximal inhibitory concentration: 245 nM
The estimate for compound 4 lay 41-fold (1.61 log units) below the measured number; the whole stated range lies below it.
By their numbers in this assay, from the lowest: compounds 2, 1 and 3 (each within the scatter of the next, the first and the last beyond it); then compound 4.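

Methylsulfonyl on the amine nitrogen in the ring is a far larger change than any alkyl swap shown there: replacing cyclobutyl gives a 110-fold higher number from compound 3 to compound 4 (2.03 log units; beyond the scatter) and replacing ethyl gives a 350-fold higher number from compound 2 to compound 4 (2.54 log units; beyond the scatter), against only a 3.3-fold higher number from compound 2 to compound 3 (0.52 log units; beyond the scatter) for the one earlier step at this nitrogen. The 4-(methylsulfonyl)piperazin-1-yl group also separates clearly from the 4-methyl-1,4-diazepan-1-yl group, with a 190-fold higher number from compound 1 to compound 4 (2.28 log units; beyond the scatter), so compound 4 stands apart from all three compounds with a carbon substituent on this nitrogen. No measurement available here bears on the origin of this step.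

On these data alone, it remains open whether an acetyl group, an ethylsulfonyl group or a 2-hydroxyethyl chain on this nitrogen would fall with compound 4 or with compounds 1, 2 and 3. Also open, as far as these compounds go, is how methylsulfonyl in place of methyl would read on the 4-methyl-1,4-diazepan-1-yl group.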